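Replacing cycloheptyl with trifluorophenyl on the piperazine-type nitrogen

The compounds below may be only part of what the source reports. "The series", "measured", "known", "first", "only" and "open" are said of these compounds alone.

Of the compounds shown here, three sharing one core have been measured in a functional assay on CHO cells with adenosine receptor A1 (Homo sapiens) as the target, read by cAMP accumulation and immunoassay, with a stated time of 6 min, tested at 1 uM; a higher number here means a weaker effect of the compound at the concentration tested, a lower number a stronger effect. Compound 1 `Nc1scc(CN2CCN(c3ccc(Cl)cc3Cl)CC2)c1C(=O)c1ccc(Cl)cc1` gives -54%, compound 2 `COc1ccc(N2CCN(Cc3csc(N)c3C(=O)c3ccc(Cl)cc3)CC2)cc1` gives -15%, and compound 3 `Nc1scc(CN2CCN(C3CCCCCC3)CC2)c1C(=O)c1ccc(Cl)cc1` gives 3.7%. Compound 3 thus stands at the highest number of the three: it lies a number 18.7 percentage points higher from compound 2 to compound 3 (beyond the scatter) and a number 57.7 percentage points higher from compound 1 to compound 3 (beyond the scatter), both beyond the scatter, so compound 3 shows the weakest effect of the measured set.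

Compound 4 `Nc1scc(CN2CCN(c3c(F)cc(F)cc3F)CC2)c1C(=O)c1ccc(Cl)cc1` differs from compound 3 in one place: 2,4,6-trifluorophenyl in place of cycloheptyl on an amine nitrogen in a ring

Within the data shown here, two measured steps bear on this change, both running the other way. Going from cycloheptyl to an aromatic ring on that nitrogen, the number fell a number 18.7 percentage points higher from compound 2 to compound 3 (beyond the scatter) read in reverse, and going from cycloheptyl to 2,4-dichlorophenyl it fell a number 57.7 percentage points higher from compound 1 to compound 3 (beyond the scatter) read in reverse. The group entering compound 4 is an aromatic ring bearing three halogens, closer to the 2,4-dichlorophenyl of compound 1 than to the 4-methoxyphenyl of compound 2. A large downward step is therefore expected, roughly a number 38.7 percentage points lower from compound 3 to compound 4 (beyond the scatter). Compound 4 is estimated to give -35% in this assay, within a range from -65% to 0%.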

Compound 4, a percentage reported as activity, at one concentration (the size of the read-out at that concentration, not a potency): -56%
Compound 4: middle estimate off by 21 percentage points, on the high side, and the stated range covers the measured number.
By their numbers in this assay, from the lowest: compounds 4 and 1 (each within the scatter of the next); then compound 2; then compound 3.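

In this assay, 2,4,6-trifluorophenyl in place of cycloheptyl on the ring amine nitrogen gives a number 59.7 percentage points lower from compound 3 to compound 4 (beyond the scatter) and, in place of 4-methoxyphenyl, gives a number 41 percentage points lower from compound 2 to compound 4 (beyond the scatter) for this change, so a second halogen-bearing aromatic ring now stands well apart from both of those groups. Exchanging 2,4-dichlorophenyl for it gives a number 2 percentage points lower from compound 1 to compound 4 (within the scatter) and thus shows that, at this position, a fluorine-bearing phenyl ring and a chlorine-bearing one cannot be told apart in this read-out, while the 4-methoxyphenyl of compound 2 shows that an aromatic ring alone does not reach their level. Nothing at hand gives a reason for this split among the groups on that nitrogen.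

Going by these compounds, whether an unsubstituted phenyl ring, a phenyl ring carrying a single fluorine, or one carrying a trifluoromethyl or nitrile group would fall with the two halogen-bearing rings remains open. Also open, on these data alone, is whether a bromine-bearing phenyl ring or a pyridine ring on the same nitrogen would give a comparable number.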